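The source may hold more compounds than are shown below. What is called first, only, known or untested is meant among the compounds shown, and "the series" means these compounds.

Measured compounds:
compound 1, `COc1ccc(C=C(C(=O)c2cc(OC)c(OC)c(OC)c2)c2ccccc2)cc1[N+](=O)[O-]`: > 10000000 nM
compound 2, `COc1ccc(C(=Cc2ccc(OC)c(F)c2)C(=O)c2cc(OC)c(OC)c(OC)c2)cc1`: 450000 nM
compound 3, `COc1ccc(C=C(C(=O)c2cc(OC)c(OC)c(OC)c2)c2ccccc2O)cc1`: 240000 nM

In a functional assay on K562 cells (Homo sapiens) for antiproliferative activity, read by MTT assay, with a stated time of 5 days (a higher number here means a weaker inhibitor, a lower number a stronger inhibitor), compound 1 returns only a limit, > 10000000 nM, and no number. Among the two numbers shown, compound 2 with 450000 nM is the higher, and compound 3 with 240000 nM is its nearest neighbour, the gap between them lying within the scatter of repeated measurements, so no order between compound 2 and compound 3 can be read.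

Compound 4, `COc1ccc(C=C(C(=O)c2cc(OC)c(OC)c(OC)c2)c2ccc(C)cc2)cc1F`, has not yet been measured. It differs from compound 2 in one place, (methyl in place of methoxy on an aromatic carbon), on an aromatic carbon of a six-membered aromatic ring of carbon only, para to a large group. Within the data shown here, no pair of measured compounds shows what this change does in this assay, so the size and direction of the step are not known from the data; the expectation is for a step of no more than the usual scatter, in either direction.

Compound 4 is therefore estimated at 500000 nM, with a range from 150000 nM to 2000000 nM, which means an expected step of a 1.1-fold higher number from compound 2 to compound 4 (0.05 log units; within the scatter).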

Compound 4, half-maximal inhibitory concentration: 570000 nM
The estimate for compound 4 lay 1.1-fold (0.06 log units) below the measured number; the measured number falls inside the stated range.
By their numbers in this assay, from the lowest: compounds 3, 2 and 4 (each within the scatter of the next, the first and the last beyond it). At a limit, above all of these: compound 1.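

In this assay, among these compounds, the change from 4-methoxyphenyl to 4-methylphenyl, para to a large group, gives the first step that can be read between two measured compounds: a 1.3-fold higher number from compound 2 to compound 4 (0.10 log units; within the scatter). At this position, then, no difference can be read between methoxy and methyl, even though methyl carries neither the oxygen nor the hydrogen-bond acceptor counted for methoxy, and the data give no cause for this. Compound 1 alone gives a limit and no number, while the two compounds of this step both give numbers: the limit of > 10000000 nM in this assay, at which 1 of the 4 values shown sits.

No other pair among the compounds shown differs in one place, so all other steps cannot be read, and this single step says nothing about the other places on the shared core. Going by these compounds, what an amine, a carboxylic acid or a longer chain such as ethyl or propyl would do at this position remains open, as does whether methyl and methoxy would also stay within the scatter of each other on a core carrying other groups.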